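Swapping the Anilino Substituent: What to Expect for Compound 4

The compounds below may be only part of what the source reports. "The series", "measured", "known", "first", "only" and "open" are said of these compounds alone.

Measured in a functional assay on A549 cells (Homo sapiens) for cytotoxicity, read by sulforhodamine B assay, with a stated time of 72 h (a lower number here means a stronger inhibitor, a higher number a weaker inhibitor), three compounds have a number so far:

compound 1, `CCS(=O)(=O)Nc1cc(-c2ccc3ncnc(Nc4ccc(OC(F)(F)F)cc4)c3c2)cnc1OC`, gives 25400 nM
compound 2, `CCCCS(=O)(=O)Nc1cc(-c2ccc3ncnc(Nc4cccc(C(=O)OCC)c4)c3c2)cnc1OC`, gives 42300 nM
compound 3, `COC(=O)c1cccc(Nc2ncnc3ccc(-c4cnc(OC)c(NS(=O)(=O)c5ccc(F)cc5F)c4)cc23)c1`, gives 10500 nM

Compound 1 stands second highest of these three numbers. Its nearest neighbour is compound 2, whose number is within the usual scatter of the number for compound 1, so the two cannot be ordered. The furthest is compound 3, whose number lies beyond the scatter below that of compound 1. Going by the values given here, no single-point step links any two of these measured compounds, so the three values stand on their own and the shared core of compound 1 carries no recorded step of its own.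

Compound 4, `CCS(=O)(=O)Nc1cc(-c2ccc3ncnc(Nc4ccc(F)nc4)c3c2)cnc1OC`, is not yet measured. It differs from compound 1 in one place: 6-fluoropyridin-3-yl in place of 4-(trifluoromethoxy)phenyl on a nitrogen on an aromatic ring. Among the compounds with values here, with no comparable step among the measured compounds, nothing here points in a direction, and the three numbers seen so far all sit in a narrow band. Compound 4 is therefore expected to show no step beyond the scatter, the step being estimated as a 1.2-fold higher number from compound 1 to compound 4 (0.07 log units; within the scatter). The number for compound 4 in this assay is estimated at 30000 nM, within a range of 10000 nM to 90000 nM.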

Compound 4, half-maximal inhibitory concentration: 6720 nM
The estimate for compound 4 lay 4.5-fold (0.65 log units) above the measured number; the measured number lies below the stated range.
By their numbers in this assay, from the lowest: compounds 4 and 3 (each within the scatter of the next); then compounds 1 and 2 (each within the scatter of the next).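

In this assay, going by these compounds alone, this is the first single change that can be read on the shared core, and the group on a nitrogen on an aromatic ring proves able to move the number: a 3.8-fold lower number from compound 1 to compound 4 (0.58 log units; beyond the scatter), a modest step. The change exchanges 4-(trifluoromethoxy)phenyl, with 11 heavy atoms and a six-membered aromatic ring of carbon only, for 6-fluoropyridin-3-yl, with 7 heavy atoms and a six-membered aromatic ring with a hetero atom, while the counts of hydrogen-bond donors and acceptors stay the same. Nothing measured here bears on why the number falls with this change.

The compounds shown leave open which part of the change carries the step, since neither 4-fluorophenyl nor unsubstituted pyridin-3-yl stands among them to separate the ring nitrogen from the fluorine. Also open, on these data alone, is whether 6-methoxypyridin-3-yl or 6-aminopyridin-3-yl in the same place would lower the number further, and whether the step holds when a longer chain replaces the ethyl on the sulfonyl group.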